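Swapping the Acid for a Diol on the Amide Nitrogen

The source may report more compounds than this note shows. Statements on the series, on what has been measured and on what is new or still open speak of the compounds shown alone.

Compound 1 `CCn1c(C(=O)Nc2cccc(C(F)(F)F)c2)ccc1C(CC)(CC)c1ccc(OCCC(O)(CC)CC)c(C)c1` gives > 50000 nM in a functional assay on MCF7 cells (Homo sapiens) for antiproliferative activity, read by MTT assay, with a stated time of 48 h (a higher number here means a weaker inhibitor, a lower number a stronger inhibitor), which is a limit of that assay and not a number.
Compound 2 `CCC(C)C(NC(=O)c1ccc(C(CC)(CC)c2ccc(OCCC(O)(CC)CC)c(C)c2)n1CC)C(=O)O` gives 11300 nM in this assay.

Among the values shown, compound 2 is the only one with an actual number; the other entry is a limit (the limit of > 50000 nM in this assay, at which 1 of the 2 values shown sits). Within the data shown here, the single measured step, an at least 4.4-fold lower number from compound 1 to compound 2 (0.64 log units; beyond the scatter), turns on what sits on the amide-type nitrogen, and the change it records is at least modest.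

Compound 3 `CCn1c(C(=O)NC(CO)CCO)ccc1C(CC)(CC)c1ccc(OCCC(O)(CC)CC)c(C)c1` is the next compound, and it differs from compound 2 at that same position: 3-hydroxy-1-(hydroxymethyl)propyl in place of 1-carboxy-2-methylbutyl on an amide-type nitrogen. The measured step shows that this nitrogen tolerates a change from an aryl group to a carboxy-bearing chain, but it does not show how the carboxy group compares with a diol, so the direction of the change from compound 2 to compound 3 is open. Near compound 2 is where compound 3 is expected to land, with an estimated step of a 1.3-fold higher number from compound 2 to compound 3 (0.12 log units; within the scatter) that may not exceed the scatter. The estimate for compound 3 is 15000 nM, with a range from 5000 nM to 50000 nM.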

Compound 3, half-maximal inhibitory concentration: 31400 nM
Beside the measured number, compound 3's estimate is 2.1-fold (0.32 log units) below it; the measured number falls inside the stated range.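

The new result shows that two chains without a ring are not interchangeable on this amide-type nitrogen in this assay: 3-hydroxy-1-(hydroxymethyl)propyl in place of 1-carboxy-2-methylbutyl gives a 2.8-fold higher number from compound 2 to compound 3 (0.44 log units; beyond the scatter), a difference that the earlier pair, which compared an aryl group with a chain, could not reveal. The chain holding the carboxy group thus keeps the lower number of the two, although the exchange also takes the group from 8 heavy atoms to 6, so the difference cannot be credited to the oxygen-bearing groups alone. The step of an at least 1.5-fold lower number from compound 1 to compound 3 (0.20 log units; that floor lies within the scatter) is only a floor, resting on a limit of the assay and not on a number, so the diol chain cannot be ranked against 3-(trifluoromethyl)phenyl: the limit of > 50000 nM in this assay, at which 1 of the 3 values shown sits.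

The compounds shown do not separate the carboxylic acid from the branched carbon chain that carries it. As far as these compounds go, how an amine, a single hydroxyl group or a longer diol chain on this nitrogen would read in this assay also remains open.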